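Swapping the Chlorophenyl Amide for a Benzofuran Amide

This account rests on a few compounds, and the source may have more. Where it says the series, first, only, none or still open, it means among the compounds named here.

Three compounds built on one shared core were tested in a functional assay on A2780 cells (Homo sapiens) for cytotoxicity, read by MTT assay, with a stated time of 72 h; on this read-out lower numbers stand for stronger inhibition and higher numbers for weaker inhibition:

Compound 1 `CN1[C@@H]2c3[nH]c4ccccc4c3C[C@H]1[C@H](C#N)N1[C@@H](CNC(=O)c3ccc(Cl)cc3)c3[nH]c4ccccc4c3C[C@@H]21` gives 230 nM.
Compound 2 `COc1ccc(C(=O)NC[C@H]2c3[nH]c4ccccc4c3C[C@H]3[C@H]4c5[nH]c6ccccc6c5C[C@@H]([C@H](C#N)N23)N4C)cc1` gives 320 nM.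
Compound 3 `CCc1ccc(C(=O)NC[C@H]2c3[nH]c4ccccc4c3C[C@H]3[C@H]4c5[nH]c6ccccc6c5C[C@@H]([C@H](C#N)N23)N4C)cc1` gives 670 nM.

The three differ only in the group on the aromatic ring of the amide. Compound 1 carries the lowest of the three numbers, but the gap to compound 2 is within the scatter, so the two cannot be ranked; only compound 3 stands clearly apart. The measured steps are a 1.4-fold higher number from compound 1 to compound 2 (0.14 log units; within the scatter), a 2.9-fold higher number from compound 1 to compound 3 (0.46 log units; beyond the scatter) and a 2.1-fold higher number from compound 2 to compound 3 (0.32 log units; beyond the scatter). They show that changing this ring moves this assay only modestly, never more than a few multiples.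

Compound 4 `CN1[C@@H]2c3[nH]c4ccccc4c3C[C@H]1[C@H](C#N)N1[C@@H](CNC(=O)c3cc4ccccc4o3)c3[nH]c4ccccc4c3C[C@@H]21` has not been measured. It differs from compound 1 in that (1-benzofuran-2-yl in place of 4-chlorophenyl on a carbonyl carbon). Within the data shown here, this is a larger change than any measured step, since a second ring enters rather than a single substituent swap, so the earlier steps bear on it only loosely. A modest weakening, in the direction seen for compound 3, is the most that those steps support, and a wide range is appropriate.

Compound 4 is therefore expected to give about 400 nM, somewhere between 150 nM and 1200 nM, which would mean an expected step of a 1.7-fold higher number from compound 1 to compound 4 (0.24 log units; within the scatter).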

Compound 4, half-maximal inhibitory concentration: 230 nM
Compound 4: the middle estimate sits 1.7-fold (0.24 log units) above what was measured; measured number inside the range.
By their numbers in this assay, from the lowest: compounds 1, 4 and 2 (each within the scatter of the next); then compound 3.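

In this assay, 1-benzofuran-2-yl in place of 4-chlorophenyl on the carbonyl carbon gives no change at the digits printed from compound 1 to compound 4 (within the scatter), so this position takes a group with a second aromatic ring and one hydrogen-bond acceptor without any readable shift in the number. Read against the other two amides, the same group gives a 1.4-fold lower number from compound 2 to compound 4 (0.14 log units; within the scatter) and a 2.9-fold lower number from compound 3 to compound 4 (0.46 log units; beyond the scatter); the group on this carbonyl carbon therefore need not be a substituted phenyl ring to remain level with compound 1 and compound 2, and compound 3 is still the only one of the four set apart. Nothing available here explains why the 4-chlorophenyl and 1-benzofuran-2-yl groups read alike.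

On these data alone, all four compounds keep an aromatic ring on this carbonyl carbon, so it remains open how the number would respond to a piperidine ring, a carboxylic acid or a longer alkyl chain at this place. The oxygen and the second ring of 1-benzofuran-2-yl also arrive together, and a naphthyl group, with its two carbon-only rings, would begin to separate them.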